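The compounds below may be only part of what the source reports. "The series", "measured", "known", "first", "only" and "open" are said of these compounds alone.

Measured in a functional assay on MCF7 cells (Homo sapiens) for antiproliferative activity, read by MTT assay, with a stated time of 72 h; on this read-out lower numbers stand for stronger inhibition and higher numbers for weaker inhibition:
- compound 1 `COc1ccc(/C=C2/CN(C)/C(=N/c3ccc(C(C)(C)C)cc3)S2)cc1`: 28700 nM
- compound 2 `COc1ccc(/C=C2/CN(C)/C(=N/c3ccc(C)cc3)S2)cc1`: 7600 nM
- compound 3 `COc1ccc(/C=C2/CN(C)/C(=N/c3ccc(OC)cc3)S2)cc1`: 8700 nM

Compound 3 stands level with the methyl compound and clear of the tert-butyl compound. The two steps are a 1.1-fold higher number from compound 2 to compound 3 (0.06 log units; within the scatter) and a 3.3-fold lower number from compound 1 to compound 3 (0.52 log units; beyond the scatter).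

Compound 4 `COc1ccc(/C=C2/CN(C)/C(=N/c3ccc(C(F)(F)F)cc3)S2)cc1` has trifluoromethyl in place of methoxy on an aromatic carbon. Going by the values given here, no measured compound carries trifluoromethyl, so the closest guide is earlier swaps at this same place. Only tert-butyl moved the number beyond the scatter, in a 3.8-fold lower number from compound 1 to compound 2 (0.58 log units; beyond the scatter). Methyl and methoxy did not.

In this assay, a small rise or no real change is therefore expected. The estimated step is a 1.4-fold higher number from compound 3 to compound 4 (0.14 log units; within the scatter). For compound 4 the estimate is 12000 nM, with an expected range from 6000 nM to 26000 nM.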

Compound 4, half-maximal inhibitory concentration: 24100 nM
For compound 4 the middle estimate is 2.0-fold (0.30 log units) below the measured one; the measured number falls inside the stated range.
By their numbers in this assay, from the lowest: compounds 2 and 3 (each within the scatter of the next); then compounds 4 and 1 (each within the scatter of the next).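

In this assay the position proves sensitive to more than tert-butyl alone: trifluoromethyl also weakens inhibition, with a 2.8-fold higher number from compound 3 to compound 4 (0.44 log units; beyond the scatter) and a 3.2-fold higher number from compound 2 to compound 4 (0.50 log units; beyond the scatter) as the two steps. Against the tert-butyl compound, a 1.2-fold lower number from compound 1 to compound 4 (0.08 log units; within the scatter) shows no real difference, so among these four compounds methyl and methoxy form the better pair, and trifluoromethyl and tert-butyl the poorer one.

As far as these compounds go, how a single fluorine, a hydroxyl or an amine would behave at this place remains open. No supporting measurement is available to explain why the groups divide this way.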